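Replacing a pyrazole with pyrrolidine on the benzamide ring

The source may report more compounds than this note shows. Statements on the series, on what has been measured and on what is new or still open speak of the compounds shown alone.

Measured so far:
- compound 1 `Cc1cc(C)n(-c2ccc(Cl)c(C(=O)NC(=O)Nc3nc4ccc(S(=O)(=O)CCCN5CCN(C)CC5)cc4s3)c2)n1`: 2.5
- compound 2 `CN1CCN(CCCS(=O)(=O)c2ccc3nc(NC(=O)NC(=O)c4cc(-n5cccc5)ccc4Cl)sc3c2)CC1`: 2.6
- compound 3 `Cc1ccnn1-c1ccc(Cl)c(C(=O)NC(=O)Nc2nc3ccc(S(=O)(=O)C4CCN(C)CC4)cc3s2)c1`: 2.6

In a physicochemical assay for lipophilicity (on this read-out lower numbers stand for lower lipophilicity and higher numbers for higher lipophilicity), compound 3 stands level with compound 2 at the digits shown, the two together forming the highest pair of the three, while compound 1 lies a little lower, within the scatter. Compound 4 `CN1CCC(S(=O)(=O)c2ccc3nc(NC(=O)NC(=O)c4cc(N5CCCC5)ccc4Cl)sc3c2)CC1` differs from compound 3 in one place: pyrrolidin-1-yl in place of 5-methyl-1H-pyrazol-1-yl on an aromatic carbon. Going by the values given here, the only measured step that touches this position, a number 0.10 log units higher from compound 1 to compound 2 (within the scatter), swapped one five-membered aromatic ring for another and stayed within the scatter. Among the compounds with values here, no measured step exchanges an aromatic ring for a saturated amine, so that step offers only a loose guide. Compound 4 is therefore expected to show a number 0.30 log units higher from compound 3 to compound 4 (within the scatter), and its estimated value is 2.9, within 2.4 to 3.4.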

Compound 4, distribution coefficient: 3.1
Compound 4: middle estimate off by 0.20 log units, on the low side; measured number inside the range.
By their numbers in this assay, from the lowest: compounds 1, 2 and 3 (each within the scatter of the next); then compound 4.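

Placing pyrrolidin-1-yl in place of 5-methyl-1H-pyrazol-1-yl on this aromatic carbon gives a number 0.50 log units higher from compound 3 to compound 4 (beyond the scatter) in this assay. Going by these compounds alone, this is the first step at this position to go beyond the scatter, whereas the exchange of one aromatic ring for another, a number 0.10 log units higher from compound 1 to compound 2 (within the scatter), did not. Nothing available explains the size of this step.

The compounds shown leave open whether piperidin-1-yl, morpholin-4-yl or an open-chain dimethylamino group on this carbon would give a similar step. They also leave open whether pyrrolidin-1-yl would have the same effect on the side chain of compound 1.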